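From Methoxy to 1-Hydroxypropyl on the Sulfur Chain

The source may report more compounds than this note shows. Statements on the series, on what has been measured and on what is new or still open speak of the compounds shown alone.

- compound 1 `CC(C)c1n[nH]c2c(NCc3ccc(-c4ccccn4)cc3)nc(SCCCN)nc12`: 120 nM
- compound 2 `C=CCSc1nc(NCc2ccc(-c3ccccn3)cc2)c2[nH]nc(C(C)C)c2n1`: 1010 nM
- compound 3 `COCSc1nc(NCc2ccc(-c3ccccn3)cc2)c2[nH]nc(C(C)C)c2n1`: 340 nM

All three compounds share one core and differ only in the chain on the sulfur. In a functional assay on HT cells (Homo sapiens) for antiproliferative activity, read by fluorescence, with a stated time of 72 h (on this read-out lower numbers stand for stronger inhibition of growth and higher numbers for weaker inhibition of growth), compound 3, at 340 nM, has the second highest of the three numbers. Only compound 2 sits higher, while compound 1 has the lowest number.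

The next compound, compound 4 `CCC(O)CSc1nc(NCc2ccc(-c3ccccn3)cc2)c2[nH]nc(C(C)C)c2n1`, carries 1-hydroxypropyl in place of methoxy on a saturated chain carbon bound to a sulfur.

Within the data shown here, three measured steps bear on this place. They are a 2.8-fold higher number from compound 1 to compound 3 (0.45 log units; beyond the scatter), a 3.0-fold lower number from compound 2 to compound 3 (0.47 log units; beyond the scatter) and an 8.4-fold higher number from compound 1 to compound 2 (0.93 log units; beyond the scatter). Each is beyond the scatter, so changes here do register in this assay. Even so, none of the measured compounds carries the 1-hydroxypropyl group, and the steps give no rule for its direction. The estimate therefore stays close to compound 3 at 340 nM, and its range is about as wide as the measured steps from that compound.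

The expected change is small, an estimated 1.1-fold lower number from compound 3 to compound 4 (0.05 log units; within the scatter), with no firm direction. For compound 4 the estimated value is 300 nM, with an expected range from 110 nM to 800 nM.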

Compound 4, concentration for 50% growth inhibition: 273 nM
Beside the measured number, compound 4's estimate is 1.1-fold (0.04 log units) above it; low and high end bracket the measured number.
By their numbers in this assay, from the lowest: compound 1; then compounds 4 and 3 (each within the scatter of the next); then compound 2.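

Putting 1-hydroxypropyl in place of methoxy on a saturated chain carbon bound to a sulfur gives a 1.2-fold lower number from compound 3 to compound 4 (0.10 log units; within the scatter) in this assay, so this place takes a longer chain carrying a hydrogen-bond donor with no change that can be told from the usual scatter. Compound 4 also separates from the chains on either side of it, with a 3.7-fold lower number from compound 2 to compound 4 (0.57 log units; beyond the scatter) and a 2.3-fold higher number from compound 1 to compound 4 (0.36 log units; beyond the scatter), both beyond the scatter; the 2-aminoethyl chain of compound 1 therefore still gives the strongest growth inhibition of the four, and the vinyl chain of compound 2 the weakest. No outside measurement is available to explain these differences between the chains.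

As far as these compounds go, it remains open whether an amine in place of the hydroxyl on the same chain would bring the number close to that of compound 1. From the compounds shown here alone, how a carboxylic acid or a still longer chain at this place would read also remains unknown, as does whether the order of these four chains would hold in a different kind of cell.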